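The compounds below may be only part of what the source reports. "The series", "measured", "known", "first", "only" and "open" are said of these compounds alone.

Among the compounds with values here, in a functional assay on DU-145 cells (Homo sapiens) for inhibition (on this read-out higher numbers stand for weaker inhibition and lower numbers for stronger inhibition), compound 3 `Oc1cccc(-c2cc(-c3ccccc3C(F)(F)F)cc(-c3ccccc3O)n2)c1` gives 7250 nM, the only plain number in the set. Compound 1 `Oc1ccc(-c2cc(-c3cccc(F)c3)cc(-c3ccccc3O)n2)cc1` reaches only the limit > 50000 nM there. Compound 2 `Oc1ccc(-c2cc(-c3ccc(F)cc3)cc(-c3ccccc3O)n2)cc1` likewise reaches only the limit > 50000 nM. The step that the two limits leave unreadable from compound 1 to compound 2 is therefore unreadable, since both of its compounds sit at the limit of > 50000 nM in this assay, at which 2 of the 3 values shown sit. Compound 4 `Oc1ccc(-c2cc(-c3ccccc3C(F)(F)F)cc(-c3ccccc3O)n2)cc1` differs from compound 3 by 4-hydroxyphenyl in place of 3-hydroxyphenyl on an aromatic carbon. Within the data shown here, compounds 1 and 2, which both carry a 4-hydroxyphenyl group, show only the limit, whereas compound 3 with a 3-hydroxyphenyl group shows a number; no measured step reads this particular change directly. Weaker inhibition is expected for compound 4, with a step of a 2.8-fold higher number from compound 3 to compound 4 (0.44 log units; beyond the scatter) toward the limit. Compound 4 is estimated at 20000 nM, between 6000 nM and 50000 nM, with a fair chance that only a limit is reported.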

Compound 4, half-maximal inhibitory concentration: 6690 nM
For compound 4 the middle estimate is 3.0-fold (0.48 log units) above the measured one; the measured number falls inside the stated range.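

In this assay, 4-hydroxyphenyl in place of 3-hydroxyphenyl next to the ring nitrogen leaves the read-out unchanged within the scatter, with a 1.1-fold lower number from compound 3 to compound 4 (0.03 log units; within the scatter). With 4-hydroxyphenyl held, 2-(trifluoromethyl)phenyl in place of either fluorophenyl group gives a plain number, with an at least 7.4-fold lower number from compound 2 to compound 4 (0.87 log units; beyond the scatter) and with an at least 7.4-fold lower number from compound 1 to compound 4 (0.87 log units; beyond the scatter). These two steps are only bounded, as compound 1 and compound 2 each show a limit: the limit of > 50000 nM in this assay, at which 2 of the 4 values shown sit.

Open is whether the trifluoromethyl group or its place on the phenyl ring carries this gain, since no 3- or 4-(trifluoromethyl)phenyl partner is shown. Also open, on these data alone, is how an aminophenyl or carboxyphenyl group would read in place of the hydroxyphenyl group.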